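The source may report more compounds than this note shows. Statements on the series, on what has been measured and on what is new or still open speak of the compounds shown alone.

Among the compounds with values here, compound 2 `N#CC1=C(N)Oc2c(N)cc3nc4ccccc4nc3c2C12C(=O)N(Cc1cnnn1-c1cc(Cl)ccc1Cl)c1ccccc12` carries a 2,5-dichlorophenyl on the aromatic nitrogen and in a functional assay on MCF7 cells (Homo sapiens) for antiproliferative activity, read by MTT assay, with a stated time of 48 h (on this read-out lower numbers stand for stronger inhibition and higher numbers for weaker inhibition), gives 33200 nM, the only number in the set. Compound 1 `N#CC1=C(N)Oc2c(N)cc3nc4ccccc4nc3c2C12C(=O)N(Cc1cnnn1-c1ccc([N+](=O)[O-])cc1)c1ccccc12` sits at the limit of this assay, > 50000 nM, and that is a limit rather than a number. The step of an at least 1.5-fold lower number from compound 1 to compound 2 (0.17 log units; that floor lies within the scatter) therefore rests on that limit (the limit of > 50000 nM in this assay, at which 1 of the 2 values shown sits). Compound 3 `N#CC1=C(N)Oc2c(N)cc3nc4ccccc4nc3c2C12C(=O)N(Cc1cnnn1-c1ccc(F)c(Cl)c1)c1ccccc12` differs from compound 2 by 3-chloro-4-fluorophenyl in place of 2,5-dichlorophenyl on an aromatic nitrogen. Within the data shown here, only one measured step touches this aromatic nitrogen, and it lies within the scatter, so no step beyond the scatter is expected for compound 3 in this assay. Compound 3 is estimated at 35000 nM, between 15000 nM and 80000 nM, an expected step of a 1.1-fold higher number from compound 2 to compound 3 (0.02 log units; within the scatter).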

Compound 3, half-maximal inhibitory concentration: 17800 nM
Compound 3: middle estimate off by 2.0-fold (0.29 log units), on the high side, and the stated range covers the measured number.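

In this assay, 3-chloro-4-fluorophenyl in place of 2,5-dichlorophenyl on the aromatic nitrogen gives a 1.9-fold lower number from compound 2 to compound 3 (0.27 log units; within the scatter), so these two aryl groups are not separated. This position now also shows a step beyond the scatter: an at least 2.8-fold lower number from compound 1 to compound 3 (0.44 log units; beyond the scatter). Compound 1 stands at a limit and not at a number, so that step is only a floor: the limit of > 50000 nM in this assay, at which 1 of the 3 values shown sits.

Open, from the compounds shown here alone, is whether an unsubstituted phenyl, an aminophenyl or a carboxyphenyl on this nitrogen would shift the read-out. Also open, going by these compounds, is whether any group here gives a number well under that of compound 3, 17800 nM.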